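The source may hold more compounds than are shown below. What is called first, only, known or untested is meant among the compounds shown, and "the series" means these compounds.

Among the compounds with values here, in a functional assay on HT-29 cells (Homo sapiens) for cytotoxicity, read by MTT assay, with a stated time of 3 days (on this read-out lower numbers stand for stronger inhibition and higher numbers for weaker inhibition), compound 1 `COc1ccccc1-c1cccc(O)c1` gives 22 ug/mL, the middle of the three numbers known so far. Compound 2 `Nc1ccccc1-c1cccc(O)c1` gives 9.2 ug/mL, and compound 3 `Nc1ccc(-c2cccc(O)c2)cc1` gives 49.3 ug/mL. Compound 4 `COc1ccc(-c2cccc(O)c2)c(OC)c1` differs from compound 1 by one change: methoxy in place of hydrogen on an aromatic carbon. Within the data shown here, the only measured step, a 2.4-fold lower number from compound 1 to compound 2 (0.38 log units; beyond the scatter), is modest, and it puts amino in place of methoxy rather than adding a methoxy, so it bears on this change only loosely. Among the measured compounds shown here, with no measured step that adds a methoxy, no clear shift in either direction is expected. The expected step is a 1.1-fold higher number from compound 1 to compound 4 (0.04 log units; within the scatter), likely within the scatter. Compound 4 is estimated at 24 ug/mL, with an expected range from 10 ug/mL to 55 ug/mL.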

Compound 4, half-maximal inhibitory concentration: 54 ug/mL
For compound 4 the middle estimate is 2.3-fold (0.35 log units) below the measured one; the measured number falls inside the stated range.
By their numbers in this assay, from the lowest: compound 2; then compound 1; then compounds 3 and 4 (each within the scatter of the next).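

In this assay the added methoxy, meta to a methoxy group and para to a group of 7 heavy atoms, brings a 2.5-fold higher number from compound 1 to compound 4 (0.39 log units; beyond the scatter) and so a modest weakening of inhibition. Within the data shown here, this carbon of the shared core is therefore not indifferent to substitution, something the earlier compounds, none of them changed here, could not show. Nothing available explains why the number rises.

As far as these compounds go, whether fluorine or a carboxylic acid on the same carbon would shift the number in the same way stays open. So does whether this step depends on the methoxy already on the ring.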